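The source may report more compounds than this note shows. Statements on the series, on what has been measured and on what is new or still open speak of the compounds shown alone.

Working notes on the series. Compound 1 `COc1cc2c(cc1OC)CN(S(=O)(=O)c1ccc(-n3cc(COc4ccc(C=O)cc4)nn3)cc1)CC2` carries a (4-formylphenoxy)methyl arm on the shared core. In a functional assay on A549 cells (Homo sapiens) for cytotoxicity, read by MTT assay, with a stated time of 48 h (on this read-out lower numbers stand for stronger inhibition and higher numbers for weaker inhibition), compound 1 gives 31800 nM. Compound 2 `O=c1cc(OCc2cn(-c3ccc(S(=O)(=O)N4CCc5ccccc5C4)cc3)nn2)c2ccccc2o1` gives 25300 nM in this assay, and compound 3 `O=Cc1ccc(OCc2cn(-c3ccc(S(=O)(=O)N4CCc5ccccc5C4)cc3)nn2)cc1` gives 59100 nM. On these three numbers compound 1 stands second highest, but its gaps to compound 2 and to compound 3 both lie within the scatter, so no order between compound 1 and either of them can be read.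

Within the data shown here, the one step that is beyond the scatter is a 2.3-fold higher number from compound 2 to compound 3 (0.37 log units; beyond the scatter): a trimming of the group on the oxygen on a saturated carbon, which moved the number modestly upward.

Compound 4 `COc1cc2c(cc1OC)CN(S(=O)(=O)c1ccc(-n3cc(CO)nn3)cc1)CC2` has not been measured. It differs from compound 1 by hydrogen in place of 4-formylphenyl on an oxygen on a saturated carbon, which removes the aryl group from that same oxygen altogether and is thus a further trimming in the direction taken between compound 2 and compound 3. Among the measured compounds shown here, only that single step bears on it. Compound 4 is therefore expected to show a modest rise in number, a 1.9-fold higher number from compound 1 to compound 4 (0.28 log units; within the scatter), beyond the scatter but not by much. The estimate for compound 4 in this assay is 60000 nM, with a range from 28000 nM to 130000 nM.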

Compound 4, half-maximal inhibitory concentration: 41000 nM
For compound 4 the middle estimate is 1.5-fold (0.17 log units) above the measured one; the range from low to high includes it.
By their numbers in this assay, from the lowest: compounds 2, 1, 4 and 3 (each within the scatter of the next, the first and the last beyond it).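

Hydrogen in place of 4-formylphenyl on the oxygen on a saturated carbon gives a 1.3-fold higher number from compound 1 to compound 4 (0.11 log units; within the scatter) in this assay, so on the core of compound 1 the loss of the whole aryl group, hydroxymethyl in place of (4-formylphenoxy)methyl, cannot be read as a shift in the number. Among these compounds, the earlier step at this oxygen exchanged one aromatic group for another, while this pair is the first to show the oxygen with no aromatic group on it at all, and on this core the 4-formylphenyl, with its ring and its carbonyl, makes no difference that stands out from the scatter. No measurement at hand speaks to what lies behind this result.

Still open, going by these compounds, is whether an amine or a carboxylic acid in place of the hydroxy in hydroxymethyl, or a longer chain ending in hydroxy, would move the number beyond the scatter on this core. Also open, on these data alone, is whether hydrogen in place of 4-formylphenyl on the core of compound 3 would read the same way as it does on the core of compound 1.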